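The source may hold more compounds than are shown below. What is called first, only, known or untested is meant among the compounds shown, and "the series" means these compounds.

Compound 2 `COc1ccc2[nH]c3c(c2c1)CCNC31CCN(Cc2ccc(Cl)cc2Cl)CC1` and compound 1 `COc1ccc2[nH]c3c(c2c1)CCNC31CCN(Cc2ccccc2)CC1` share the same core and differ only in the group on a saturated chain carbon bound to an amine nitrogen in a ring. In an assay on FRT cells for positive allosteric modulation of Cystic fibrosis transmembrane conductance regulator variant N1303K (Homo sapiens), in the presence of a further agent that is not named here (on this read-out lower numbers stand for an effect already at smaller amounts and higher numbers for an effect only at larger amounts of compound), compound 1 gives 12600 nM, whereas compound 2 gives 1800 nM, the lower of the two numbers shown; this step is a 7.0-fold lower number from compound 1 to compound 2 (0.85 log units; beyond the scatter). Compound 3 `COc1ccc2[nH]c3c(c2c1)CCNC31CCN(Cc2cc(F)c(F)c(F)c2)CC1` is not yet measured. Relative to compound 2 it carries 3,4,5-trifluorophenyl in place of 2,4-dichlorophenyl on a saturated chain carbon bound to an amine nitrogen in a ring. Among the measured compounds shown here, the only measured step that bears on this change is the one from compound 1 to compound 2, where a halogenated aryl in place of a plain phenyl gave a lower number. For the measured compounds named here, compound 3 keeps a halogenated aryl, but the halogen type and pattern are different, and no measured pair shows what chlorine to fluorine, or this pattern, does. The expectation is therefore that compound 3 stays closer to compound 2 than to compound 1, with a step of a 2.2-fold higher number from compound 2 to compound 3 (0.35 log units; beyond the scatter) toward a somewhat higher number. The estimate for compound 3 in this assay is 4000 nM, with a range from 1500 nM to 11000 nM.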

Compound 3, half-maximal effective concentration: 2600 nM
For compound 3 the middle estimate is 1.5-fold (0.19 log units) above the measured one, within the range that was stated.
By their numbers in this assay, from the lowest: compounds 2 and 3 (each within the scatter of the next); then compound 1.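

In this assay the change from 2,4-dichlorophenyl to 3,4,5-trifluorophenyl on a saturated chain carbon bound to an amine nitrogen in a ring gives a 1.4-fold higher number from compound 2 to compound 3 (0.16 log units; within the scatter), so this read-out does not separate the two halogenated groups. Compound 3 also stands apart from the plain phenyl of compound 1, with a 4.8-fold lower number from compound 1 to compound 3 (0.69 log units; beyond the scatter), which shows that the lower number seen with compound 2 does not depend on chlorine or on the 2,4-dichloro pattern. Among the compounds shown, both halogenated groups therefore give lower numbers than phenyl, and neither compound goes against this. No measurement available here gives a reason for this result.

The compounds shown leave open whether a single fluorine or chlorine on the phenyl would be enough, and whether the halogens can be replaced by a trifluoromethyl, methoxy or nitrile group. They also do not show how this assay would respond to a pyridine in place of the phenyl, or to a longer chain between that ring and the ring nitrogen.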